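A quinazoline thioether: moving the change to the anilino nitrogen

The source may hold more compounds than are shown below. What is called first, only, known or untested is meant among the compounds shown, and "the series" means these compounds.

Compound 1: `O=C(CSc1nc(Nc2ccccc2)c2ccccc2n1)Nc1ccc(Br)cc1` — 8450 nM
Compound 2: `O=C(CSc1nc(Nc2ccccc2)c2ccccc2n1)Nc1ccc(Cl)cc1Cl` — 9110 nM
Compound 3: `C=CC(=O)Nc1cccc(NC(=O)CSc2nc(Nc3ccccc3Cl)c3ccccc3n2)c1` — 14400 nM

Of the compounds shown here, three sharing one core have been measured in a functional assay on PC-3 cells (Homo sapiens) for inhibition, read by MTT assay, with a stated time of 72 h; a lower number here means a stronger inhibitor, a higher number a weaker inhibitor. For the measured compounds named here, compound 1 gives 8450 nM and compound 2 gives 9110 nM; the step of a 1.1-fold higher number from compound 1 to compound 2 (0.03 log units; within the scatter) is the only one-place step between them. Compound 3 gives 14400 nM, the highest of the three numbers, but its gaps to compound 1 and to compound 2 both fall within the scatter, so no order among the three can be claimed.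

Compound 4 is `C=CC(=O)Nc1cccc(NC(=O)CSc2nc(Nc3ccc(CC)cc3)c3ccccc3n2)c1`. It differs from compound 3 by 4-ethylphenyl in place of 2-chlorophenyl on a nitrogen on an aromatic ring. Going by the values given here, the one measured step concerns the amide-type nitrogen, not the nitrogen on the aromatic ring, so no measured step bears directly on this change, and the data give no reason to expect a shift beyond the scatter in this assay. The estimate for compound 4 is therefore 12000 nM, with a range from 5000 nM to 30000 nM, which means an expected step of a 1.2-fold lower number from compound 3 to compound 4 (0.08 log units; within the scatter).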

Compound 4, half-maximal inhibitory concentration: 24300 nM
Compound 4: the middle estimate sits 2.0-fold (0.31 log units) below what was measured; the range from low to high includes it.
By their numbers in this assay, from the lowest: compounds 1, 2, 3 and 4 (each within the scatter of the next, the first and the last beyond it).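

For the compounds shown here, the first measured step at the nitrogen on an aromatic ring, in this assay, is a 1.7-fold higher number from compound 3 to compound 4 (0.23 log units; within the scatter), for 4-ethylphenyl in place of 2-chlorophenyl. The earlier compounds shown here offered no such step, and this one shows that the two groups cannot be told apart at this position, even though the chlorine is gone and an ethyl group is carried on the ring. No available evidence explains the values of this pair.

The compounds shown leave open whether any group on this nitrogen would give a step beyond the scatter, such as a phenyl ring carrying an amine or a carboxylic acid, or one with a longer chain in place of the ethyl. They also leave open whether the same change would read alike on compound 1.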